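The source may report more compounds than this note shows. Statements on the series, on what has been measured and on what is new or still open speak of the compounds shown alone.

Measured so far:
Compound 1, `CCc1cccc(NC(=O)CN2CCN(c3ccccn3)CC2)c1`: 58%
Compound 2, `Cc1cccc(NC(=O)CN2CCN(c3ccc(Cl)cn3)CC2)c1`: "not active" (no number reported)
Compound 3, `Cc1cccc(NC(=O)CN2CCN(c3ncccn3)CC2)c1`: 64.6%

All three share a core in which an amide links an aryl ring to a six-membered ring holding two nitrogens, and the read-out is a functional assay on cells for agonist activity at D(4) dopamine receptor (Homo sapiens), read by TR-FRET and cAMP accumulation, with a stated time of 30 min; a higher number here means a larger maximal response, a lower number a smaller maximal response. In this assay compound 3 gives 64.6%, and compound 1 gives 58%; these two numbers lie within the usual scatter of each other, so no order between them can be claimed. Compound 2 is reported as "not active" (no number reported), with no number attached.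

The next compound is compound 4, `Cc1cccc(NC(=O)CN2CCN(c3ccccn3)CC2)c1`, which has not yet been measured. It differs from compound 3 in one place: pyridin-2-yl in place of pyrimidin-2-yl on an amine nitrogen in a ring. For the measured compounds named here, no pair of measured compounds differing in only one place is available, so the size of this step has to be estimated from what is in hand. Compound 1 with the same pyridin-2-yl group on the ring nitrogen gives 58%, which suggests the step stays within the scatter rather than moving far in either direction. The expected step from compound 3 to compound 4 is therefore a number 4.6 percentage points lower from compound 3 to compound 4 (within the scatter). Compound 4 is expected to give 60%, with a range from 45% to 75%.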

Compound 4, largest response reached (Emax), in percent of the reference or control that the assay uses: 64.2%
Estimate against measurement, compound 4: 4.2 percentage points below; the measured number falls inside the stated range.
By their numbers in this assay, from the lowest: compounds 1, 4 and 3 (each within the scatter of the next).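

In this assay, for the compounds shown here, pyridin-2-yl in place of pyrimidin-2-yl on an amine nitrogen in a ring gives a number 0.4 percentage points lower from compound 3 to compound 4 (within the scatter), the first direct comparison at this position, and it shows that going from 2 hydrogen-bond acceptors to 1 in this group does not measurably separate the two compounds. Compound 4 also links to compound 1 through a change elsewhere, hydrogen in place of methyl on a saturated chain carbon bound to an aromatic carbon, which gives a number 6.2 percentage points higher from compound 1 to compound 4 (within the scatter), so this exchange does not separate its pair either. No measurement in hand offers an explanation for either result.

Compound 2, which carries a chlorine on its pyridine ring, is reported as "not active" (no number reported), while compound 4 gives 64.2%, so the chlorine marks a clear contrast whose size cannot be stated. From the compounds shown here alone, it remains open whether a phenyl ring on the same ring nitrogen, or a longer chain such as propyl on the other aromatic ring, would keep the maximal response in this assay near these values.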